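The source may report more compounds than this note shows. Statements on the series, on what has been measured and on what is new or still open speak of the compounds shown alone.

Compound 1 `O=C(NO)c1ccc(NCc2nc(-c3ccccc3)nn2-c2cccc(Cl)c2)cc1` was measured in an assay on Sf9 cells for inhibition of protein deacetylase HDAC6 (Homo sapiens), read by fluorescence, with a stated time of 40 min, tested at 100 nM (on this read-out higher numbers stand for more inhibition at the one concentration tested (going by the name of the read-out) and lower numbers for less inhibition), where compound 1 gives 62.3%. This is the lower of the two numbers seen so far: in this assay compound 2 `O=C(NO)c1ccc(NCc2nc(-c3cccs3)nn2-c2ccc(O)cc2)cc1` gives 79.6%, a gap beyond the usual scatter. Compound 3 `O=C(NO)c1ccc(NCc2nc(-c3ccccc3)nn2-c2ccccc2Cl)cc1` has not yet been measured. It differs from compound 1 in one place: 2-chlorophenyl in place of 3-chlorophenyl on an aromatic nitrogen. Among the measured compounds shown here, no measured pair shows a change of this kind, so nothing is known about its effect; the step of a number 2.3 percentage points lower from compound 1 to compound 3 (within the scatter) is expected to be small, within the scatter, in either direction. Compound 3 is therefore estimated at 60%, with a range from 40% to 78%.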

Compound 3, a percentage reported as inhibition, at one concentration (the size of the read-out at that concentration, not a potency): 64.6%
For compound 3 the middle estimate is 4.6 percentage points below the measured one; low and high end bracket the measured number.
By their numbers in this assay, from the lowest: compounds 1 and 3 (each within the scatter of the next); then compound 2.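

The exchange of 3-chlorophenyl for 2-chlorophenyl on the aromatic nitrogen gives a number 2.3 percentage points higher from compound 1 to compound 3 (within the scatter). In this assay, this first measured step at this position therefore separates neither compound from the other, so for this pair the place of the chlorine on the phenyl group makes no difference that can be read. Nothing available bears on this result.

Still open, on these data alone, is how this position responds to a different group, such as plain phenyl, methoxyphenyl or aminophenyl, in place of the chlorophenyl groups.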